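The source may report more compounds than this note shows. Statements on the series, on what has been measured and on what is new or still open speak of the compounds shown alone.

In a functional assay on PC-3 cells (Homo sapiens) for inhibition (on this read-out lower numbers stand for stronger inhibition and higher numbers for weaker inhibition), compound 1 (`Cc1c(C(=O)N/N=C\c2ccccc2F)oc2cccc(O)c12`) gives >= 40000 nM, which is a limit of the assay and not a number. Compound 1 therefore stands at the limit of >= 40000 nM in this assay, at which 1 of the 2 values shown sits. Compound 2 (`Cc1c(C(=O)N/N=C\c2ccccc2C(F)(F)F)oc2cccc(O)c12`) does give a number, 26200 nM.

Compound 3 (`Cc1c(C(=O)N/N=C\c2cccc(F)c2)oc2cccc(O)c12`) has not yet been measured. It has the same atoms as compound 1, joined differently, with 3-fluorophenyl in place of 2-fluorophenyl on a carbon with a double bond to nitrogen. The fluorine stays in the molecule, and only its place on the ring changes.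

Within the data shown here, only one measured step offers any guide, and it is a different kind of change: trifluoromethyl in place of fluoro on an aromatic carbon. Compound 2 shows that step as an at least 1.5-fold lower number from compound 1 to compound 2 (0.18 log units; that floor lies within the scatter), so even swapping the group did not give a change clearly beyond the scatter. A smaller edit is therefore expected to give no step beyond the scatter in this assay, and a further limit would be no surprise. The expected step is an at least 1.0-fold lower number from compound 1 to compound 3 (0.02 log units; that floor lies within the scatter). For compound 3 the estimated value is 38000 nM, with an expected range from 18000 nM to 80000 nM.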

Compound 3, half-maximal inhibitory concentration: >= 40000 nM
Compound 3 ended at the assay's limit (the forecaster's own chance of this, stated with the estimate: 55%); middle value at least 1.0-fold (0.02 log units) from the limit.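

Among these compounds, compound 1 and compound 3 both end at a limit of the assay and not at a number, so no step between them can be read in this assay: the limit of >= 40000 nM in this assay, at which 2 of the 3 values shown sit.

Going by these compounds, whether 3-fluorophenyl in place of 2-fluorophenyl changes inhibition at all, and in which direction, stays open.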